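A few compounds are considered here, and "the series" means these few. Any claim that something is new, unique, unknown or untested is made for them only; others in the source may bear on it.

Compound 1 `NC(=O)c1c(NC(=O)c2ccccc2Cl)sc2c1CCNC2` carries a free amine nitrogen in its ring. In a functional assay on MKN-74 cells (Homo sapiens) for antiproliferative activity, with a stated time of 24 h (on this read-out higher numbers stand for weaker inhibition and lower numbers for stronger inhibition), compound 1 gives 28700 nM, the highest of the three numbers recorded here. Compound 3 `NC(=O)c1c(NC(=O)c2cccc([N+](=O)[O-])c2)sc2c1CCN(Cc1ccc(Cl)cc1Cl)C2` gives 16500 nM, within the scatter of compound 1, while compound 2 `NC(=O)c1c(NC(=O)c2ccccc2F)sc2c1CCN(Cc1c(Cl)cccc1Cl)C2` gives 7430 nM, a gap beyond the scatter. Compound 4 `NC(=O)c1c(NC(=O)c2ccccc2Cl)sc2c1CCN(C(=S)Nc1ccccc1)C2` is not yet measured; it differs from compound 1 by a group of 9 heavy atoms (7 carbon, 1 nitrogen, 1 sulfur; one six-membered aromatic ring of carbon only) in place of a hydrogen atom, on an amine nitrogen in a ring. Both compound 2 at 7430 nM and compound 3 at 16500 nM carry a group on that ring amine nitrogen and sit at lower numbers than compound 1, so a moderate downward step, roughly at the edge of the scatter, is expected for the change to compound 4. Compound 4 is estimated at 12000 nM, range 4000 nM to 35000 nM, the expected step being a 2.4-fold lower number from compound 1 to compound 4 (0.38 log units; beyond the scatter).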

Compound 4, half-maximal inhibitory concentration: 15600 nM
Compound 4: middle estimate off by 1.3-fold (0.11 log units), on the low side, within the range that was stated.
By their numbers in this assay, from the lowest: compound 2; then compounds 4, 3 and 1 (each within the scatter of the next).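

Held to a single change on an amine nitrogen in a ring, the core of compound 1 gives a 1.8-fold lower number from compound 1 to compound 4 (0.26 log units; within the scatter) in this assay when the hydrogen atom is replaced. A free ring amine nitrogen is therefore not needed to keep this read-out, and a group of this size with an aromatic ring is accepted there without a clear shift. Nothing on hand bears on the reason for this step. Still open, from the compounds shown here alone, is whether a smaller acetyl or methyl group on this nitrogen, or oxygen in place of the sulfur of the entering group, would give a step beyond the scatter.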